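Swapping a Methoxypiperidine Urea for a Bicyclic Amide

The source may report more compounds than this note shows. Statements on the series, on what has been measured and on what is new or still open speak of the compounds shown alone.

Compound 1, `O=C(N1CCC(F)CC1)N1CC(c2nc(-c3cccc(Cl)c3)no2)C1`, gives 990 nM in an assay on HEK293 cells for positive allosteric modulation of metabotropic glutamate receptor 5 (Homo sapiens), read by FLIPR; a higher number here means that more compound is needed for the effect, a lower number that less compound is needed.
Compound 2, `O=C(N1CCCCC1)N1CC(c2nc(-c3cccc(Cl)c3)no2)C1`, gives 370 nM in this assay.
Compound 3, `COC1CCN(C(=O)N2CC(c3nc(-c4cccc(Cl)c4)no3)C2)CC1`, reaches only the limit of > 10000 nM in this assay, so no number is known for it.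

Compound 3 therefore stands at the weak end of the three, sitting at the limit of > 10000 nM in this assay, at which 1 of the 3 values shown sits. The step to compound 4, `O=C([C@H]1CC2CCC1C2)N1CC(c2nc(-c3cccc(Cl)c3)no2)C1`, is a group of 7 heavy atoms (7 carbon; 2 five-membered non-aromatic rings of carbon only) in place of a group of 8 heavy atoms (6 carbon, 1 nitrogen, 1 oxygen; one six-membered non-aromatic ring with 1 hetero atom), on a carbonyl carbon. For the measured compounds named here, no measured step exchanges the whole saturated ring in this way; the measured steps only vary the substituent on that ring. Those steps show that a hydrogen there gives the lowest number, a 2.7-fold lower number from compound 1 to compound 2 (0.43 log units; beyond the scatter), while a methoxy gives the highest, an at least 10-fold higher number from compound 1 to compound 3 (1.00 log units; beyond the scatter) and an at least 27-fold higher number from compound 2 to compound 3 (1.43 log units; beyond the scatter). Compound 4 carries no methoxy and no ring nitrogen or oxygen in this part, so a move back down, away from the limit, is expected, though its size is uncertain. Compound 4 is expected to show an at least 6.6-fold lower number from compound 3 to compound 4 (0.82 log units; beyond the scatter) in this assay, landing at an estimated 1500 nM, within 300 nM to 8000 nM.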

Compound 4, half-maximal effective concentration: 74 nM
Estimate against measurement, compound 4: 20-fold (1.31 log units) above; the whole stated range lies above it.
By their numbers in this assay, from the lowest: compound 4; then compound 2; then compound 1. At a limit, above all of these: compound 3.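

The earlier compounds shown here varied only a substituent on the saturated ring, whereas compound 4 shows that the carbonyl carbon can carry a group of carbon only, with no ring nitrogen, and it gives the lowest number of the four in this assay. Against the ring without a substituent the change is a 5.0-fold lower number from compound 2 to compound 4 (0.70 log units; beyond the scatter), and against the fluoro ring it is a 13-fold lower number from compound 1 to compound 4 (1.13 log units; beyond the scatter), so the result does not rest on losing the methoxy alone. The step of an at least 130-fold lower number from compound 3 to compound 4 (2.13 log units; beyond the scatter) starts from compound 3, whose value is a limit and not a number: the limit of > 10000 nM in this assay, at which 1 of the 4 values shown sits.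

Going by these compounds, whether the lower number follows the loss of the ring nitrogen or the two-ring shape stays open, and a cyclohexyl group on the carbonyl carbon would separate the two. On these data alone, how the other stereoisomer of compound 4 would read also stays open.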